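A few compounds are considered here, and "the series" means these few. Any claim that something is new, unique, unknown or untested is made for them only; others in the source may bear on it.

Compound 2 `Nc1cc(N)c2nc(-c3ccccc3)c(Oc3ccc(F)cc3)nc2c1` is one of three close analogues built on the same shared core. In a functional assay on NCI/ADR-RES cells (Homo sapiens) for inhibition, read by sulforhodamine B assay, with a stated time of 48 h (on this read-out higher numbers stand for weaker inhibition of growth and lower numbers for stronger inhibition of growth), compound 2 gives 36300 nM. Compound 1 `Nc1cc(N)c2nc(-c3ccccc3)c(Sc3ccc(F)cc3)nc2c1` gives 34700 nM in this assay, and compound 3 `COc1cc(CNc2nc3cc(N)cc(N)c3nc2-c2ccccc2)cc(OC)c1OC` gives 21900 nM. The three numbers lie within the scatter of one another, so compound 2 is not set apart from either of the other two, and none of the three can be called stronger or weaker than the rest.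

Compound 4 `Nc1cc(N)c2nc(-c3ccccc3)c(NCc3ccc(F)cc3)nc2c1` has not yet been measured. It differs from compound 2 in one place: (4-fluorobenzyl)amino in place of 4-fluorophenoxy on an aromatic carbon. Within the data shown here, the only measured step that bears on a change of this kind is the one from compound 1 to compound 2, where 4-fluorophenoxy took the place of (4-fluorophenyl)sulfanyl and gave a 1.0-fold higher number from compound 1 to compound 2 (0.02 log units; within the scatter). Exchanging one linking atom for another thus left the number where it was. The move to (4-fluorobenzyl)amino is a somewhat larger change, but nothing measured here points in either direction.

Compound 4 is therefore expected to give 32000 nM, with a range from 13000 nM to 80000 nM. The expected step from compound 2 to compound 4 is a 1.1-fold lower number from compound 2 to compound 4 (0.05 log units; within the scatter), staying within the scatter.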

Compound 4, concentration for total growth inhibition: 5750 nM
Beside the measured number, compound 4's estimate is 5.6-fold (0.75 log units) above it, outside the stated range (below it).
By their numbers in this assay, from the lowest: compound 4; then compounds 3, 1 and 2 (each within the scatter of the next).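

In this assay, the aromatic carbon next to the ring nitrogen proves sensitive to what it carries: (4-fluorobenzyl)amino in place of 4-fluorophenoxy gives a 6.3-fold lower number from compound 2 to compound 4 (0.80 log units; beyond the scatter), and the same group in place of (4-fluorophenyl)sulfanyl gives a 6.0-fold lower number from compound 1 to compound 4 (0.78 log units; beyond the scatter). The earlier exchange between the two other groups, with a 1.0-fold higher number from compound 1 to compound 2 (0.02 log units; within the scatter), gave no hint of this, whereas the new group brings a nitrogen with 1 hydrogen-bond donor and a carbon between that nitrogen and the ring, two changes made together. No measurement at hand explains why this group gives the lower number.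

The compounds shown leave open whether the nitrogen or the added carbon accounts for the step: 4-fluoroanilino would keep the nitrogen without the added carbon, while (4-fluorobenzyl)oxy would keep the carbon without the nitrogen. They also leave open how far the effect extends along a longer chain such as [2-(4-fluorophenyl)ethyl]amino, and whether the fluorine on the ring has any part in it, which a plain benzylamino group would address.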